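The compounds below may be only part of what the source reports. "The series", "measured", "known", "first", "only" and "open" are said of these compounds alone.

Working notes on the series in a functional assay on MDA-MB-231 cells (Homo sapiens) for inhibition, read by sulforhodamine B assay, with a stated time of 48 h; on this read-out higher numbers stand for lower toxicity in this test and lower numbers for higher toxicity in this test.

Compound 1 `O=C(Nc1cccc(-n2cc(-c3ccncc3)c(-c3ccc(Cl)c(O)c3)n2)c1)Nc1ccc(Cl)c(Cl)c1` is known only by a limit of the assay: in this assay compound 1 gives > 32500 nM. Compound 2 `COc1cc(-c2nn(-c3cccc(NC(=O)c4ccc(Cl)c(C(F)(F)F)c4)c3)cc2-c2ccncc2)ccc1Cl` sits at the same kind of limit, and in this assay compound 2 gives > 32500 nM. On the numbers shown, compound 1 therefore stands at the ceiling of what the assay reports rather than at a measured point, and the limit of > 32500 nM in this assay, at which 2 of the 2 values shown sit, sums up what is known of the two measured compounds. Within the data shown here, no step between measured compounds exists that differs in one place.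

Compound 3 `O=C(Nc1cccc(-n2cc(-c3ccncc3)c(-c3ccc(Cl)c(O)c3)n2)c1)Nc1cccc(C(F)(F)F)c1` is the next compound to be measured in this assay. It differs from compound 1 by 3-(trifluoromethyl)phenyl in place of 3,4-dichlorophenyl on an amide-type nitrogen. Both measured compounds give only a limit, so the change gives no foothold for a direction. Against the limit of compound 1, the expected step is a step that the limit leaves unreadable from compound 1 to compound 3, that is none beyond the scatter, with the most likely outcome again a limit. Compound 3 is thus estimated at 40000 nM, within 15000 nM to 100000 nM.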

Compound 3, concentration lethal to 50% of the cells: > 32500 nM
Compound 3 gave a limit, no number (the forecaster's own chance of this, stated with the estimate: 75%); the middle value lies beyond the limit too.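

In this assay compound 3 gives > 32500 nM, which is a limit of the assay and not a number. Compound 1 is also known only by a limit, so no step can be read between compound 1 and compound 3. Still open is whether 3-(trifluoromethyl)phenyl in place of 3,4-dichlorophenyl changes the read-out at all, as all that is known is this: the limit of > 32500 nM in this assay, at which 3 of the 3 values shown sit.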